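A few compounds are considered here, and "the series" means these few. Any claim that something is new, unique, unknown or untested is made for them only; others in the source may bear on it.

Compound 1 `COc1ccc(/C=C/C(=O)c2ccccc2-c2cccc(F)c2)cc1`: 280 nM
Compound 2 `COc1ccc(/C=C/C(=O)c2ccccc2-c2ccc(OC)c(OC)c2OC)cc1O`: 190 nM
Compound 3 `COc1ccc(C(=O)/C=C/c2ccccc2-c2ccc(F)cc2)cc1`: 8200 nM

All three values come from a functional assay on A549 cells (Homo sapiens) for antiproliferative activity, read by sulforhodamine B assay, with a stated time of 48 h; a higher number here means a weaker inhibitor, a lower number a stronger inhibitor. Compound 3 has the highest number of the three, so it is the weakest inhibitor here. Its gap to each of the other two lies well beyond the scatter of repeated measurements. The values of the other two, compound 1 at 280 nM and compound 2 at 190 nM, lie within that scatter of each other.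

The next molecule is compound 4 `COc1ccc(C(=O)/C=C/c2ccccc2-c2ccc(F)nc2)cc1`, which has not yet been measured. It carries 6-fluoropyridin-3-yl in place of 4-fluorophenyl on an aromatic carbon. The swap keeps the fluorine and the size of the ring, and the ring stays aromatic.

Among the compounds with values here, no pair of measured compounds differs in one place only, so the data offer no direct precedent for this swap. The best starting point is therefore compound 3 at 8200 nM, and the expectation is for no change beyond the scatter in either direction. The expected step is a 1.1-fold higher number from compound 3 to compound 4 (0.04 log units; within the scatter), with wide uncertainty. For compound 4 the estimated value is 9000 nM, with an expected range from 3000 nM to 27000 nM.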

Compound 4, half-maximal inhibitory concentration: > 50000 nM
Compound 4 ended at the assay's limit (the forecaster's own chance of this, stated with the estimate: 15%); middle value at least 5.5-fold (0.74 log units) from the limit.
By their numbers in this assay, from the lowest: compounds 2 and 1 (each within the scatter of the next); then compound 3. At a limit, above all of these: compound 4.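

Within the data shown here, until now, no two measured compounds differed in one place only, so nothing showed how this position, on an aromatic carbon ortho to a large group, responds to a single change. Putting 6-fluoropyridin-3-yl in place of 4-fluorophenyl gives an at least 6.0-fold higher number from compound 3 to compound 4 (0.78 log units; beyond the scatter) in this assay, which shows that this position does not tolerate every swap, even one that keeps the fluorine and the ring size and adds only a ring nitrogen with its hydrogen-bond acceptor. Compound 4 stands at a limit of the assay, not at a measured number, so the step gives only a minimum: the limit of > 50000 nM in this assay, at which 1 of the 4 values shown sits.

The compounds shown leave open whether the ring nitrogen alone accounts for this step, as neither a plain pyridin-3-yl without the fluorine nor a pyrimidine ring appears among them. They also leave open whether the same swap would have a similar effect on the core of compound 1, which differs from compound 3 in more than one place.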